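Working notes: from compound 2 to compound 3

This account rests on a few compounds, and the source may have more. Where it says the series, first, only, none or still open, it means among the compounds named here.

Measured so far:
compound 1 `CC#C[C@H]1CN(S(=O)(=O)c2ccc(N)nc2)CCN1c1ccc(S(=O)(=O)NC)cn1`: 381 nM
compound 2 `CC#C[C@H]1CN(S(=O)(=O)c2ccc(N)nc2)CCN1c1ccc(C(O)(COC)C(F)(F)F)cc1`: 202 nM

In an assay on cells (Hepatocyte) for inhibition of glucokinase regulatory protein (Mus musculus), with stated times of 20 min and 40 min (a higher number here means that more compound is needed for the effect, a lower number that less compound is needed), compound 1 gives 381 nM, and compound 2 gives 202 nM. Compound 2 has the lowest of the two numbers, but its gap to compound 1 lies within the scatter, so no order between the two can be read from these values. Going by the values given here, no step between measured compounds that differ in one place is available, so the size of a change at this position has not yet been seen.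

Compound 3 `CC#C[C@H]1CN(S(=O)(=O)c2ccc(N)nc2)CCN1c1ccc([C@](O)(CO)C(F)(F)F)cc1` is not yet measured. Relative to compound 2 it differs as follows: a group of 8 heavy atoms (3 carbon, 2 oxygen, 3 fluorine; no ring) in place of a group of 9 heavy atoms (4 carbon, 2 oxygen, 3 fluorine; no ring), on an aromatic carbon. Among the compounds with values here, with no measured step to guide the size, the expected change is small, not beyond the scatter, in either direction. For compound 3 the estimate in this assay is 250 nM, with a range of 100 nM to 600 nM. The step this estimate implies, a 1.2-fold higher number from compound 2 to compound 3 (0.09 log units; within the scatter), is expected to stay within the scatter.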

Compound 3, half-maximal effective concentration: 98 nM
Beside the measured number, compound 3's estimate is 2.6-fold (0.41 log units) above it, outside the stated range (below it).
By their numbers in this assay, from the lowest: compound 3; then compounds 2 and 1 (each within the scatter of the next).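

In this assay this position now has its first measured step: 1,2-dihydroxy-1-(trifluoromethyl)ethyl on the aromatic carbon, in place of the group of 9 heavy atoms, gives a 2.1-fold lower number from compound 2 to compound 3 (0.31 log units; beyond the scatter), a modest change that lies just beyond the scatter. The read-out therefore responds to a small edit at this position, one in which the entering group counts 2 hydrogen-bond donors against 1 and carries 1 defined stereocentre. No measurement shown here accounts for the lower number.

The compounds shown leave open how the opposite configuration at that stereocentre would read, and whether an amine, a carboxylic acid or a longer chain in place of the terminal hydroxyl would extend or reverse the step. On these data alone, with one step only, it also remains open whether the same change would carry over to another core.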